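Swapping 3-fluorophenyl for 2-chlorophenyl on the benzyl ether

The source may hold more compounds than are shown below. What is called first, only, known or untested is meant among the compounds shown, and "the series" means these compounds.

In a functional assay on a cell-free system (plasma, Oryctolagus cuniculus) for inhibition, with stated times of 5 min, 1 min and 6 min (on this read-out lower numbers stand for stronger inhibition and higher numbers for weaker inhibition), compound 1 (`CCOC(=O)c1c(C)nc(-c2cccc(C#N)c2)n1OC(C)C`) gives 6740 nM and compound 2 (`CCOC(=O)c1c(C)nc(-c2cccc(C#N)c2)n1OCc1cccc(F)c1`) gives 22400 nM as the higher of the two numbers. Compound 2 is thus the weaker inhibitor of this pair, and the gap lies beyond the scatter. Compound 3 (`CCOC(=O)c1c(C)nc(-c2cccc(C#N)c2)n1OCc1ccccc1Cl`) keeps the shared core of compound 2 and carries 2-chlorophenyl in place of 3-fluorophenyl on a saturated chain carbon bound to an oxygen on an aromatic ring, with the difference counted as 2-chlorophenyl in place of 3-fluorophenyl on a saturated chain carbon bound to an oxygen on an aromatic ring and nothing else altered. Within the data shown here, only one measured step touches this substituent, namely a 3.3-fold higher number from compound 1 to compound 2 (0.52 log units; beyond the scatter) on exchanging isopropyl for 3-fluorobenzyl. Among the measured compounds shown here, that modest step replaced the whole group, so it shows only that a change here can move the number. For the measured compounds named here, no measured step exchanges one substituted phenyl for another, so compound 2 remains the closest guide. No change beyond the scatter is expected in this assay and no direction is favoured. The expected change is a 1.1-fold lower number from compound 2 to compound 3 (0.05 log units; within the scatter) in this estimate. Compound 3 is estimated at 20000 nM (range 7000 nM to 55000 nM).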

Compound 3, half-maximal inhibitory concentration: 8710 nM
For compound 3 the middle estimate is 2.3-fold (0.36 log units) above the measured one, and the stated range covers the measured number.
By their numbers in this assay, from the lowest: compounds 1 and 3 (each within the scatter of the next); then compound 2.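

In this assay the exchange of 3-fluorophenyl for 2-chlorophenyl on a saturated chain carbon bound to an oxygen on an aromatic ring gives a 2.6-fold lower number from compound 2 to compound 3 (0.41 log units; beyond the scatter) with the heavy-atom count unchanged, so a swap between two substituted phenyl groups moves the number on its own. The earlier step, a 3.3-fold higher number from compound 1 to compound 2 (0.52 log units; beyond the scatter) on going from isopropyl to 3-fluorobenzyl, therefore does not hold for every benzyl ether: the step to 2-chlorobenzyl reads a 1.3-fold higher number from compound 1 to compound 3 (0.11 log units; within the scatter) and stays within the scatter. Among these three compounds, compound 2 alone stands apart, and the higher number goes with the 3-fluorobenzyl group rather than with the benzyl ether as such.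

On these data alone, compound 2 and compound 3 differ in both the halogen and the substituted ring place, and the share of each in the step stays open. Also open, as far as these compounds go, is how an unsubstituted benzyl, a methoxybenzyl or a chain ending in an amine would read at this oxygen. No measurement at hand accounts for the gap between the two halogenated benzyl groups.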